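An ethynyl swap in a series held at its limit

The source may report more compounds than this note shows. Statements on the series, on what has been measured and on what is new or still open speak of the compounds shown alone.

Compound 1 `Cc1ccc(S(=O)(=O)N[C@@H](CC(=O)NC(C)(C)C)C(=O)NCCNC(=O)c2ccccc2)cc1`: > 11100 nM
Compound 2 `Cc1ccc(S(=O)(=O)N[C@@H](CC(=O)NC(C)(C)C)C(=O)NCCNC(=O)c2cccc(C(C)C)c2)cc1`: > 11100 nM
Compound 3 `Cc1ccc(S(=O)(=O)N[C@@H](CC(=O)NC(C)(C)C)C(=O)NCCNC(=O)c2ccc(F)c(F)c2)cc1`: > 11100 nM

In an ADME assay on Karpas-1106P cells (Homo sapiens) for cytotoxicity (a lower number here means that less compound is needed, a higher number that more compound is needed for the effect), compound 3 gives > 11100 nM, which is a limit of the assay and not a number. Compound 1 and compound 2 are reported the same way, so the picture so far is the limit of > 11100 nM in this assay, at which 3 of the 3 values shown sit.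

Compound 4 `C#Cc1cccc(C(=O)NCCNC(=O)[C@H](CC(=O)NC(C)(C)C)NS(=O)(=O)c2ccc(C)cc2)c1` keeps the rest of compound 3 and differs in one place: 3-ethynylphenyl in place of 3,4-difluorophenyl on a carbonyl carbon. In words, 3-ethynylphenyl stands in place of 3,4-difluorophenyl on a carbonyl carbon.

Three measured changes bear on this: a step that the two limits leave unreadable from compound 1 to compound 2, a step that the two limits leave unreadable from compound 1 to compound 3 and a step that the two limits leave unreadable from compound 2 to compound 3. None of them has a readable size, and none gives a direction. All three compounds remain at the limit, so no step beyond the scatter is expected in this assay. The expected change is a step that the limit leaves unreadable from compound 3 to compound 4. Compound 4 is estimated at 14000 nM, with an expected range from 6000 nM to 30000 nM.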

Compound 4, half-maximal effective concentration: > 11100 nM
Compound 4: no number, only a limit (the forecaster's own chance of this, stated with the estimate: 85%); the middle value is on the limit's open side.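

In this assay compound 4 gives > 11100 nM, which is a limit of the assay and not a number. The steps from compound 1, compound 2 and compound 3 to compound 4 cannot be read. The compounds shown leave open how much of any of them is needed for the effect, because all stand at one reading: the limit of > 11100 nM in this assay, at which 4 of the 4 values shown sit.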